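The source may report more compounds than this note shows. Statements on the series, on what has been measured and on what is new or still open speak of the compounds shown alone.

Compound 1 `C[C@@H]1CN(c2sc(C3COC3)nc2-c2nc3ccccc3[nH]2)CCN1C(=O)Cn1cnc2cccnc21`: 38 mL.min-1.g-1
Compound 2 `CCOc1ncc(-c2nc(C(F)(F)F)sc2N2CCN(C(=O)Cn3ccc4cccnc43)[C@H](C)C2)cn1`: 316 mL.min-1.g-1
Compound 3 `CCOc1ncc(-c2nc(C(F)(F)F)sc2N2CCN(C(=O)Cn3ccc4cnccc43)[C@H](C)C2)cn1`: 656 mL.min-1.g-1

In a toxicity assay on microsomes from liver (Homo sapiens) for metabolic stability, read by LC-MS, using NADPH, tested at 1 uM (a higher number here means faster removal of the compound, a lower number slower removal), compound 2, at 316 mL.min-1.g-1, stands second highest of the three, with compound 3 higher and compound 1 lower. Compound 4 `CCOc1ncc(-c2nc(C(F)(F)F)sc2N2CCN(C(=O)Cn3cnc(C(F)(F)F)n3)[C@H](C)C2)cn1`, not yet measured, carries 3-(trifluoromethyl)-1H-1,2,4-triazol-1-yl in the change (a group of 9 heavy atoms (3 carbon, 3 nitrogen, 3 fluorine; one five-membered aromatic ring with 3 hetero atoms) in place of a group of 9 heavy atoms (7 carbon, 2 nitrogen; one five-membered aromatic ring with 1 hetero atom, one six-membered aromatic ring with 1 hetero atom), on a saturated chain carbon bound to a carbonyl carbon). Among the measured compounds shown here, one measured step bears on this place: a 2.1-fold higher number from compound 2 to compound 3 (0.32 log units; beyond the scatter), which is modest. For the measured compounds named here, compound 1 differs from compound 2 in more than one place and gives no clean step. The data show no direction for a swap to a single ring, so only a tentative, modest fall is expected, and the expected step is a 1.6-fold lower number from compound 2 to compound 4 (0.20 log units; within the scatter). For compound 4 the estimate is 200 mL.min-1.g-1, with an expected range of 80 mL.min-1.g-1 to 500 mL.min-1.g-1.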

Compound 4, intrinsic clearance in microsomes: < 10 mL.min-1.g-1
Compound 4 gave a limit, no number (the forecaster's own chance of this, stated with the estimate: 3%); middle value at least 20-fold (1.30 log units) away from the limit.
By their numbers in this assay, from the lowest: compound 1; then compound 2; then compound 3. At a limit, below all of these: compound 4.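

Compound 4 gives a limit, not a number, in this assay: the limit of < 10 mL.min-1.g-1 in this assay, at which 1 of the 4 values shown sits. Among the compounds shown here, the earlier step compared only one two-ring group with another on this saturated chain carbon bound to a carbonyl carbon, whereas 3-(trifluoromethyl)-1H-1,2,4-triazol-1-yl gives an at least 31-fold lower number from compound 2 to compound 4 (1.49 log units; beyond the scatter) and an at least 65-fold lower number from compound 3 to compound 4 (1.81 log units; beyond the scatter), both far larger than a 2.1-fold higher number from compound 2 to compound 3 (0.32 log units; beyond the scatter). This place therefore tolerates much larger changes in clearance than the earlier step showed.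

On these data alone, it remains open whether the step belongs to the triazole ring or to its trifluoromethyl group, which a plain 1,2,4-triazol-1-yl or a methyl-bearing triazole would separate. As far as these compounds go, whether the same swap acts similarly on the core of compound 1 is also open.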